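A few compounds are considered here, and "the series" means these few. Any claim that something is new, unique, unknown or untested is made for them only; others in the source may bear on it.

Among the measured compounds shown here, in a functional assay on the whole organism with Mus musculus as the target (on this read-out lower numbers stand for an effect already at smaller amounts and higher numbers for an effect only at larger amounts of compound), compound 1 `Cc1c(N)cc2c(c1C)OC(C)(C)C2` gives 24.4 mg/kg, the only actual number so far. Compound 2 `CC1(C)Cc2cc(N)ccc2O1` is recorded only as a limit, > 100 mg/kg. Compound 3 `Cc1c(C)c2c(c(N(C)C)c1N)CC(C)(C)O2` keeps the core of compound 1 and carries dimethylamino in place of hydrogen on an aromatic carbon, ortho to an amino group (dimethylamino in place of hydrogen on an aromatic carbon). For the measured compounds named here, no measured step bears on this change, so only a modest shift toward smaller doses is expected in this assay, hardly beyond the scatter. The expected step, a 1.5-fold lower number from compound 1 to compound 3 (0.18 log units; within the scatter), is an estimate only. For compound 3 the estimated dose is 16 mg/kg, within a range of 5 mg/kg to 50 mg/kg.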

Compound 3, dose for 50% inhibition: 22.3 mg/kg
Beside the measured number, compound 3's estimate is 1.4-fold (0.14 log units) below it; low and high end bracket the measured number.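

Dimethylamino in place of hydrogen on the aromatic carbon ortho to an amino group gives a 1.1-fold lower number from compound 1 to compound 3 (0.04 log units; within the scatter) in this assay, so this position takes the group with no change beyond the scatter. Among the compounds shown here, this is the first measured step at this position, which the earlier compounds could not show. Nothing at hand gives a reason for this result.

As far as these compounds go, how a methoxy group, a carboxylic acid or a longer chain on this carbon would read stays open. So does whether dimethylamino would behave alike on a core without the two methyl groups.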